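The compounds below may be only part of what the source reports. "The series", "measured", "known", "first", "only" and "open" are said of these compounds alone.

Measured so far in an assay on LtK cells with ATP-sensitive inward rectifier potassium channel 11 (Homo sapiens) as the target; a higher number here means that more compound is needed for the effect, a lower number that less compound is needed:
compound 1 `O=C(NCCCCCCCl)Nc1c(C(O)(C(F)(F)F)C(F)(F)F)ccc2ccccc12`, giving 4840 nM
compound 2 `O=C(Nc1c(C(O)(C(F)(F)F)C(F)(F)F)ccc2ccccc12)c1ccc(Br)cc1`, giving 47 nM

Among the measured compounds shown here, compound 2 holds the lowest number of the two; its nearest neighbour is compound 1, and the single measured step, a 100-fold lower number from compound 1 to compound 2 (2.01 log units; beyond the scatter), is large and well beyond the scatter.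

Compound 3 `O=C(Nc1c(C(O)(C(F)(F)F)C(F)(F)F)ccc2ccccc12)c1cccnc1` differs from compound 2 at one point: pyridin-3-yl in place of 4-bromophenyl on a carbonyl carbon. For the measured compounds named here, only one step is measured, and it concerns exchanging the (6-chlorohexyl)amino chain for an aromatic ring on the carbonyl carbon; no measured pair shows what exchanging one six-membered aromatic ring for another does, so nothing bears directly on this change. The swap is small in atom count, and a step of modest size is expected, most likely upward; the estimated step is a 3.8-fold higher number from compound 2 to compound 3 (0.58 log units; beyond the scatter). For compound 3 the expected value in this assay is 180 nM, with a range from 45 nM to 800 nM.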

Compound 3, half-maximal effective concentration: 60 nM
For compound 3 the middle estimate is 3.0-fold (0.48 log units) above the measured one; the measured number falls inside the stated range.
By their numbers in this assay, from the lowest: compounds 2 and 3 (each within the scatter of the next); then compound 1.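

In this assay, on the carbonyl carbon whose other neighbour is the amide-type nitrogen, pyridin-3-yl and 4-bromophenyl are not told apart, with a 1.3-fold higher number from compound 2 to compound 3 (0.11 log units; within the scatter) as the step. The bromine can therefore go and a ring nitrogen, counted as a hydrogen-bond acceptor, can enter without a step beyond the scatter, while an 81-fold lower number from compound 1 to compound 3 (1.91 log units; beyond the scatter) shows that the large difference from the (6-chlorohexyl)amino chain holds for a second aromatic ring as well. No measurement is available that explains why these two rings read alike.

As far as these compounds go, whether the position needs an aromatic ring at all remains open, and a saturated ring such as cyclohexyl would test this. Also open, from the compounds shown here alone, is how an amine or a carboxylic acid on the ring would read.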